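Halogen change on the aryl urea of compound 2

The source may report more compounds than this note shows. Statements on the series, on what has been measured and on what is new or still open speak of the compounds shown alone.

Compound 1 `COc1cc2c(Oc3ccc(NC(=O)N/N=C/c4ccc(C(F)(F)F)cc4)cc3F)ccnc2cc1OCCCN1CCCCC1` and compound 2 `COc1cc2c(Oc3ccc(/C=N/NC(=O)Nc4ccc(F)c(F)c4)cc3F)ccnc2cc1OCCCN1CCCCC1` share one core and differ only in the terminal aryl ring. In a functional assay on HT-29 cells (Homo sapiens) for cytotoxicity, read by MTT assay, with a stated time of 72 h (a higher number here means a weaker inhibitor, a lower number a stronger inhibitor), compound 1 gives 660 nM, and in this assay compound 2 gives 490 nM; these two numbers lie within the usual scatter of each other, so compound 2 cannot be told apart from compound 1. Compound 3 `COc1cc2c(Oc3ccc(/C=N/NC(=O)Nc4ccc(F)cc4Br)cc3F)ccnc2cc1OCCCN1CCCCC1` has not been measured; it carries 2-bromo-4-fluorophenyl in place of 3,4-difluorophenyl on an amide-type nitrogen. Among the compounds with values here, no measured step informs this change, so for compound 3 no step beyond the scatter is expected, a 1.1-fold higher number from compound 2 to compound 3 (0.05 log units; within the scatter), and compound 3 is estimated at 550 nM within 250 nM to 1200 nM.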

Compound 3, half-maximal inhibitory concentration: 110 nM
For compound 3 the middle estimate is 5.0-fold (0.70 log units) above the measured one; measured number below the stated range.
By their numbers in this assay, from the lowest: compound 3; then compounds 2 and 1 (each within the scatter of the next).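

In this assay, within the data shown here, 2-bromo-4-fluorophenyl in place of 3,4-difluorophenyl on the amide-type nitrogen gives a 4.5-fold lower number from compound 2 to compound 3 (0.65 log units; beyond the scatter), the first step at this position, and it lies beyond the scatter. The halogen pattern on this terminal aryl ring therefore matters for the read-out. No measured property on hand accounts for the step. As far as these compounds go, it remains open whether the entering bromine or the altered fluorine pattern carries the step. From the compounds shown here alone, how a terminal ring bearing chlorine, a methoxy group or an amine would compare also remains open.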